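Ester to Sulfone on a Weak Inhibitor

The source may hold more compounds than are shown below. What is called first, only, known or untested is meant among the compounds shown, and "the series" means these compounds.

Of the compounds shown here, two sharing one amide core have been measured in an in vitro assay on BTI-TN-5B1-4 cells for inhibition of Amine oxidase [flavin-containing] A (Homo sapiens), read by fluorescence; a higher number here means a weaker inhibitor, a lower number a stronger inhibitor. Compound 1 `Cc1cccc(NC(=O)c2cc3ccccc3oc2=O)c1` carries a methyl group on its outer ring, and in this assay compound 1 gives 14500 nM. Compound 2 `CCOC(=O)c1ccc(NC(=O)c2cc3ccccc3oc2=O)cc1` carries an ethoxycarbonyl group instead, and in this assay compound 2 gives 16000 nM. These two numbers lie within the usual scatter of each other, so the data do not separate compound 1 from compound 2; both are weak inhibitors.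

Compound 3 `CS(=O)(=O)c1ccc(NC(=O)c2cc3ccccc3oc2=O)cc1` has not yet been measured. It differs from compound 2 in one place: methylsulfonyl in place of ethoxycarbonyl on an aromatic carbon. Among the measured compounds shown here, no measured pair in this set shows what such a swap does, so the expectation rests only on the two values seen. Since the two measured compounds sit close together, the step from compound 2 to compound 3 is expected to be a 1.1-fold higher number from compound 2 to compound 3 (0.05 log units; within the scatter), which is no change beyond the scatter. In this assay compound 3 is therefore expected to give about 18000 nM, with a plausible range from 6000 nM to 55000 nM.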

Compound 3, half-maximal inhibitory concentration: 9330 nM
Estimate against measurement, compound 3: 1.9-fold (0.29 log units) above; low and high end bracket the measured number.
By their numbers in this assay, from the lowest: compounds 3, 1 and 2 (each within the scatter of the next).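

In this assay, putting methylsulfonyl in place of ethoxycarbonyl on this aromatic carbon, para to a large group, gives a 1.7-fold lower number from compound 2 to compound 3 (0.23 log units; within the scatter), the first direct view of a single change at this position. Although sulfur enters and the two groups are built differently, the step lies within the scatter, so the data do not separate compound 2 from compound 3, and this swap cannot be called a real gain or loss. Nothing measured alongside these compounds offers an explanation for how closely the two values sit.

The compounds shown leave open whether a group of a different kind at this position, such as an amine or a carboxylic acid, would shift the number beyond the scatter. They also leave open what a longer chain in place of the methyl of methylsulfonyl would do, and whether methylsulfonyl would give a similar number at another carbon of the same ring.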